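Triazolylsulfanyl replaced by hydroxy: expectation for compound 4

The compounds below may be only part of what the source reports. "The series", "measured", "known", "first", "only" and "open" are said of these compounds alone.

Compound 1 `Nc1nnc(SC[C@H]2O[C@@H](OCc3noc(-c4ccc(Cl)cc4)n3)[C@@H]3OC4(CCCC4)O[C@@H]32)s1` and compound 3 `Nc1nnc(SC[C@H]2O[C@@H](OCc3noc(-c4ccc([N+](=O)[O-])cc4)n3)[C@@H]3OC4(CCCC4)O[C@@H]32)s1` share one core; in a functional assay on SW1573 cells (Homo sapiens) for antiproliferative activity, read by sulforhodamine B assay, with a stated time of 48 h (a higher number here means a weaker inhibitor of growth, a lower number a stronger inhibitor of growth), compound 1 gives 17000 nM, and compound 3 gives 16000 nM. Going by the values given here, the step of a 1.1-fold lower number from compound 1 to compound 3 (0.03 log units; within the scatter) is the only measured single change in the set. Compound 2 `CC1(C)O[C@H]2[C@H](OCc3noc(-c4ccc([N+](=O)[O-])cc4)n3)O[C@H](CSc3ncn[nH]3)[C@H]2O1` carries a different core. In this assay compound 2 gives > 100000 nM, which is a limit of the assay and not a number, so that compound 2 sits at the limit of > 100000 nM in this assay, at which 1 of the 3 values shown sits. Compound 4 `CC1(C)O[C@H]2[C@H](OCc3noc(-c4ccc([N+](=O)[O-])cc4)n3)O[C@H](CO)[C@H]2O1` differs from compound 2 by hydroxy in place of (1H-1,2,4-triazol-5-yl)sulfanyl on a saturated chain carbon bound to a saturated ring carbon. Among the compounds with values here, no measured step bears on this change; the one step measured, a 1.1-fold lower number from compound 1 to compound 3 (0.03 log units; within the scatter), concerns another part of the molecule and lies within the scatter. Compound 4 is expected to remain at a similar level, an expected step of a number no higher from compound 2 to compound 4 (the limit leaves the size open). Compound 4 is therefore estimated at 100000 nM, with a range from 30000 nM to 300000 nM.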

Compound 4, concentration for 50% growth inhibition: 60000 nM
Estimate against measurement, compound 4: 1.7-fold (0.22 log units) above, within the range that was stated.
By their numbers in this assay, from the lowest: compounds 3 and 1 (each within the scatter of the next); then compound 4. At a limit, above all of these: compound 2.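

In this assay, the change at this saturated chain carbon gives an at least 1.6-fold lower number from compound 2 to compound 4 (0.22 log units; that floor lies within the scatter). Compound 2 stands at a limit of the assay, not at a number: the limit of > 100000 nM in this assay, at which 1 of the 4 values shown sits. Of the compounds shown on this core, only compound 4 gives a number, 60000 nM, so (1H-1,2,4-triazol-5-yl)sulfanyl is not required for a measurable value here.

As far as these compounds go, the true size of the step stays open, and its floor lies within the scatter. Also open, from the compounds shown here alone, is whether an amine or a carboxylic acid in place of hydroxy would shift the number.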